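The source may hold more compounds than are shown below. What is called first, only, known or untested is meant among the compounds shown, and "the series" means these compounds.

Compound 3 `OCCOCn1cnc2c(Cl)c(Cl)ccc21` has been tested in a functional assay on KB cells (Homo sapiens) for inhibition; on this read-out higher numbers stand for weaker inhibition and lower numbers for stronger inhibition. In this assay compound 3 gives > 100000 nM, which is a limit of the assay and not a number. Two relatives stand at the same boundary. Compound 1 `OCCOCn1c(Cl)nc2c(Cl)c(Cl)ccc21` gives > 100000 nM in this assay, a limit. Compound 2 `Nc1nc2c(Cl)c(Cl)ccc2n1COCCO` gives > 100000 nM in this assay, likewise a limit. The steps a step that the two limits leave unreadable from compound 1 to compound 2, a step that the two limits leave unreadable from compound 1 to compound 3 and a step that the two limits leave unreadable from compound 2 to compound 3 cannot be read, since the limit of > 100000 nM in this assay, at which 3 of the 3 values shown sit, holds every value shown.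

Compound 4 `OCCOCn1c(S)nc2c(Cl)c(Cl)ccc21` is not yet measured. It differs from compound 3 by sulfanyl in place of hydrogen on an aromatic carbon, the new group standing between two ring nitrogen atoms, next to the ring atom that bears the (2-hydroxyethoxy)methyl group. For the measured compounds named here, no measured step bears directly on this change; every step among compounds 1, 2 and 3 runs from one limit to another without readable size, and chloro or amino at this same aromatic carbon gave no number either. Compound 4 is therefore expected to show a step that the limit leaves unreadable from compound 3 to compound 4, nothing beyond the scatter. The value of compound 4 is estimated at 150000 nM, most probably again only a limit, within 40000 nM to 600000 nM.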

Compound 4, half-maximal inhibitory concentration: > 100000 nM
Compound 4: only a limit was reported (the forecaster's own chance of this, stated with the estimate: 85%); the middle value is on the limit's open side.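

In this assay compound 4 gives > 100000 nM, a limit and not a number. The steps to compound 4 from compound 1, compound 2 and compound 3 cannot be read, since all four share one boundary: the limit of > 100000 nM in this assay, at which 4 of the 4 values shown sit.

The compounds shown leave open whether any group on this aromatic carbon changes inhibition in this assay.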